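Swapping a Carbamate Cap for a Methoxyphenylsulfonyl Group

The source may report more compounds than this note shows. Statements on the series, on what has been measured and on what is new or still open speak of the compounds shown alone.

The three compounds here share one core and differ only in the group attached to the terminal amine nitrogen of a hydrazide. Compound 1, `CC[C@H](C)[C@H](NC(=O)c1cccc(Cn2ccnc2)c1)C(=O)NNS(=O)(=O)c1ccccc1`, carries a phenylsulfonyl group there. In an assay on HEK293 cells for displacement of a labelled ligand from Type-2 angiotensin II receptor (Homo sapiens), tested at 1 uM (a higher number here means a stronger effect of the compound at the concentration tested, a lower number a weaker effect), compound 1 gives 6%, a weak effect at the concentration tested. Compound 2, `CC[C@H](C)[C@H](NC(=O)c1cccc(Cn2ccnc2)c1)C(=O)NNC(=O)OC(C)(C)C`, carries a tert-butoxycarbonyl group instead, and in this assay compound 2 gives "not determined" (no result reported), so no number is available for it and it cannot be placed on the scale at all.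

Compound 3, `CC[C@H](C)[C@H](NC(=O)c1cccc(Cn2ccnc2)c1)C(=O)NNS(=O)(=O)c1ccc(OC)cc1`, is the next step from compound 2. The change is (4-methoxyphenyl)sulfonyl in place of tert-butoxycarbonyl on an amine nitrogen. For the measured compounds named here, since compound 2 has no reported result, the size of this step cannot be computed; the only guide is compound 1, whose structure is close to that of compound 3 apart from the methoxy group on the aromatic ring. On that basis the expectation for the step in this assay is a small one, in either direction, not beyond the usual scatter of such measurements. Compound 3 is therefore estimated to give 8% in this assay, with a likely range from -5% to 25%.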

Compound 3, a percentage reported as inhibition, at one concentration (the size of the read-out at that concentration, not a potency): 3%
Compound 3: the middle estimate sits 5 percentage points above what was measured, within the range that was stated.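

In this assay, methoxy in place of hydrogen on the aromatic ring of the sulfonyl group gives a number 3 percentage points lower from compound 1 to compound 3 (within the scatter), so this substitution yields no difference that can be told apart from the scatter of the measurement, and both sulfonyl compounds stay at the weak end of the scale at the concentration tested. For the compounds shown here, this is the first comparison at this position that can be read, whereas the step from the tert-butoxycarbonyl group of compound 2 to the (4-methoxyphenyl)sulfonyl group of compound 3 cannot be read, as compound 2 has no reported result. No measurement shown here offers an explanation for the result.

How a carbamate cap compares with a sulfonyl cap on this amine nitrogen therefore remains an open question. Also open, as far as these compounds go, is whether an amine or a carboxylic acid on the aromatic ring, or a longer carbon chain in place of that ring on the sulfonyl group, would give a clearly larger read-out than the phenylsulfonyl group of compound 1.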